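The source may hold more compounds than are shown below. What is called first, only, known or untested is meant among the compounds shown, and "the series" means these compounds.

Measured compounds:
compound 1, `COc1cc2ncnc(N3CCc4ccccc43)c2cc1NC(=O)/C=C/C(C)C`, 6410 nM in a functional assay on A549 cells (Homo sapiens) for antiproliferative activity, read by MTT assay, with a stated time of 72 h; a lower number here means a stronger inhibitor, a higher number a weaker inhibitor
compound 2, `COc1cc2ncnc(N3CCc4ccccc43)c2cc1NC(=O)/C=C/CN(C)C`, 2040 nM
compound 3, `COc1cc2ncnc(N3CCc4ccccc43)c2cc1NC(=O)/C=C/CN1CCCC1`, 1210 nM

Compound 3 gives the lowest number of the three in this assay. Its distance from compound 2 lies within the scatter, while the step of a 5.3-fold lower number from compound 1 to compound 3 (0.72 log units; beyond the scatter) lies beyond it. Compound 4, `COc1cc2ncnc(N3CCc4ccccc43)c2cc1NC(=O)/C=C/CN1CCN(C)CC1`, differs from compound 3 by 4-methylpiperazin-1-yl in place of pyrrolidin-1-yl on a saturated chain carbon bound to a double-bonded chain carbon. The step that bears on this change is a 1.7-fold lower number from compound 2 to compound 3 (0.23 log units; within the scatter), an exchange of one amine for another at the same place, which stayed within the scatter. The steps of a 3.1-fold lower number from compound 1 to compound 2 (0.50 log units; beyond the scatter) and a 5.3-fold lower number from compound 1 to compound 3 (0.72 log units; beyond the scatter) changed a different kind of group and bear on it less. Compound 4 is therefore expected to show no step beyond the scatter, a 1.2-fold higher number from compound 3 to compound 4 (0.06 log units; within the scatter). The estimate for compound 4 is 1400 nM, between 600 nM and 3500 nM.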

Compound 4, half-maximal inhibitory concentration: 5360 nM
Beside the measured number, compound 4's estimate is 3.8-fold (0.58 log units) below it, and the stated range ends below it.
By their numbers in this assay, from the lowest: compounds 3 and 2 (each within the scatter of the next); then compounds 4 and 1 (each within the scatter of the next).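

In this assay, the earlier exchange of one amine for another at this saturated chain carbon stayed within the scatter, but 4-methylpiperazin-1-yl does not behave like the other two amines (a 4.4-fold higher number from compound 3 to compound 4 (0.65 log units; beyond the scatter); a 2.6-fold higher number from compound 2 to compound 4 (0.42 log units; beyond the scatter)). Compound 4 also cannot be told apart from the isopropyl compound 1 (a 1.2-fold lower number from compound 1 to compound 4 (0.08 log units; within the scatter)), so an amine at this place does not by itself secure the lower number. Nothing available here explains the difference. On these data alone, it remains open whether a morpholine or piperidine ring at this place would track with pyrrolidin-1-yl or with 4-methylpiperazin-1-yl.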